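The compounds below may be only part of what the source reports. "The series", "measured", "known", "first", "only" and "open" are said of these compounds alone.

Measured in an ADME assay on BJ cells (Homo sapiens) for cytotoxicity, read by luminescence, with a stated time of 72 h; a higher number here means that more compound is needed for the effect, a lower number that less compound is needed:

- Compound 1 `CCOC(=O)c1c(-c2cccc(-c3ccccc3)c2)[nH]c2cc(OC)c(Cl)cc2c1=O`: > 21500 nM (a limit)
- Compound 2 `CCOC(=O)c1c(-c2cccc(Cl)c2)[nH]c2cc(OC)c(Cl)cc2c1=O`: > 21500 nM (a limit)

As far as these compounds go, neither result is a true number, so the exact position of compound 2 is unknown. Compound 2 sits at the limit of > 21500 nM in this assay, at which 2 of the 2 values shown sit.

Compound 3 `CCOC(=O)c1c(-c2cccc(Br)c2)[nH]c2cc(OC)c(Cl)cc2c1=O` has bromo in place of chloro on an aromatic carbon, meta to a large group (bromo in place of chloro on an aromatic carbon). Among the compounds with values here, the only measured step that bears on this change is a step that the two limits leave unreadable from compound 1 to compound 2, where chloro takes the place of phenyl on an aromatic carbon. Within the data shown here, with that step as the only guide, no change beyond the scatter is expected in this assay, in either direction, and another limit is the likeliest report. The expected change is a step that the limit leaves unreadable from compound 2 to compound 3. Compound 3 is estimated at 30000 nM, with an expected range of 12000 nM to 60000 nM.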

Compound 3, half-maximal effective concentration: > 21500 nM
Compound 3 ended at the assay's limit; the forecaster's own chance of this, stated with the estimate: 90%; the middle value is on the limit's open side.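

No step can be read between compound 1, compound 2 and compound 3, since all three results are limits and not numbers: the limit of > 21500 nM in this assay, at which 3 of the 3 values shown sit.

The compounds shown leave open at what concentration each reaches the effect in this assay, and so whether phenyl, chloro or bromo makes any difference there.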